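A few compounds are considered here, and "the series" means these few. Any claim that something is new, unique, unknown or untested is made for them only; others in the source may bear on it.

Measured so far:
compound 1, `COc1ccc(F)cc1CNCCCNc1ccnc2cc(-c3ccccc3)ccc12`, gives 2960 nM in an ADME assay on HepG2 cells (Homo sapiens) for cytotoxicity, read by luminescence, CellTiter-Glo and ATP content, with a stated time of 72 h; a higher number here means that more compound is needed for the effect, a lower number that less compound is needed;
compound 2, `COc1ccc(F)cc1CNCCCNc1ccnc2cc(Cc3cccc(C(F)(F)F)c3)ccc12`, gives 440 nM;
compound 3, `COc1ccc(F)cc1CNCCCNc1ccnc2cc(Oc3ccc(Cl)cc3)ccc12`, gives 4500 nM.

Compound 3 carries the largest number of the three. Its distance to compound 1 is small, the step of a 1.5-fold higher number from compound 1 to compound 3 (0.18 log units; within the scatter) lying within the scatter, whereas the step of a 10-fold higher number from compound 2 to compound 3 (1.01 log units; beyond the scatter) is beyond it, so compound 3 is clearly separated only from compound 2.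

The next compound, compound 4, `COc1ccc(F)cc1CNCCCNc1ccnc2cc(Oc3ccccc3)ccc12`, differs from compound 3 in one place: hydrogen in place of chloro on an aromatic carbon. Among the measured compounds shown here, no measured step changes a substituent on the 4-chlorophenoxy group itself; the three measured steps swap the whole group on the aromatic carbon of the shared core. The closest point of comparison is the step of a 1.5-fold higher number from compound 1 to compound 3 (0.18 log units; within the scatter), where a phenyl was replaced by 4-chlorophenoxy without a change beyond the scatter, and the large steps of a 6.7-fold lower number from compound 1 to compound 2 (0.83 log units; beyond the scatter) and a 10-fold higher number from compound 2 to compound 3 (1.01 log units; beyond the scatter) concern the 3-(trifluoromethyl)benzyl group, which is absent here. Removing the chloro is therefore expected to produce no step beyond the scatter in this assay, that is a 1.2-fold lower number from compound 3 to compound 4 (0.07 log units; within the scatter). Compound 4 is estimated at 3800 nM, with a range from 1500 nM to 9500 nM.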

Compound 4, half-maximal effective concentration: 1500 nM
Estimate against measurement, compound 4: 2.5-fold (0.40 log units) above, and the stated range covers the measured number.
By their numbers in this assay, from the lowest: compound 2; then compounds 4, 1 and 3 (each within the scatter of the next, the first and the last beyond it).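

In this assay, the chloro para to a large group proved to matter, since removing it gave a step beyond the scatter (a 3.0-fold lower number from compound 3 to compound 4 (0.48 log units; beyond the scatter)), the first measured change made on the 4-chlorophenoxy group itself rather than an exchange of the whole group on the shared core. Phenoxy and phenyl on that aromatic carbon of the core remain within the scatter of each other (a 2.0-fold lower number from compound 1 to compound 4 (0.30 log units; within the scatter)), so the chloro step separates compound 3 from compound 4 even though each of them lies within the scatter of compound 1, while 3-(trifluoromethyl)benzyl remains clearly apart from phenoxy (a 3.4-fold higher number from compound 2 to compound 4 (0.53 log units; beyond the scatter)). The compounds shown offer no measurement that explains why the chloro changes the number in this way.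

As far as these compounds go, it remains open whether the step is particular to chloro or would also appear with a fluoro, a methyl, a methoxy or an amine at the same place on the ring. From the compounds shown here alone, it also remains open how much of the low number of compound 2 belongs to the trifluoromethyl and how much to the carbon link, a question that an unsubstituted benzyl or a 3-(trifluoromethyl)phenoxy group at this position would address.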